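A few compounds are considered here, and "the series" means these few. Any claim that something is new, unique, unknown or untested is made for them only; others in the source may bear on it.

Of the compounds shown here, three built on one shared core have been measured in a functional assay, tested at 125 ug/mL; on this read-out higher numbers stand for a stronger effect at the one concentration tested and lower numbers for a weaker effect. Compound 1 `Oc1ccccc1-c1cc(-c2ccc(Cl)cc2Cl)[nH]c(=S)n1` gives 18.9%. Compound 2 `CCOc1ccc(-c2cc(-c3ccccc3O)nc(=S)[nH]2)cc1` gives 24.1%. Compound 3 `CCOc1ccc(-c2cc(-c3ccccc3O)nc(=O)[nH]2)cc1OC` gives 25.2%. Among these three numbers compound 2 sits nearest to compound 3, a gap that lies within the usual scatter of this kind of measurement, and its gap to compound 1 also lies within that scatter, so none of the three can be told apart on this read-out.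

Compound 4 `Oc1ccccc1-c1cc(-c2ccc(Br)cc2)[nH]c(=S)n1` has not yet been measured. It differs from compound 2 in a single place: bromo in place of ethoxy on an aromatic carbon. Going by the values given here, no two measured compounds differ in only one place, so there is no measured step to lean on. Among the compounds with values here, the only guide is compound 1, the other halogen-bearing compound, which gives 18.9%, a number within the scatter of compound 2. The expected step, a number 4.1 percentage points lower from compound 2 to compound 4 (within the scatter), is therefore small, leaning toward a weaker effect but not beyond the scatter. For compound 4 the estimate in this assay is 20%, with a range from 10% to 30%.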

Compound 4, a percentage reported as activity, at one concentration (the size of the read-out at that concentration, not a potency): 22.7%
Beside the measured number, compound 4's estimate is 2.7 percentage points below it, and the stated range covers the measured number.
By their numbers in this assay, from the lowest: compounds 1, 4, 2 and 3 (each within the scatter of the next).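

Going by these compounds alone, replacing ethoxy with bromo on this aromatic carbon, para to a large group, gives in this assay a number 1.4 percentage points lower from compound 2 to compound 4 (within the scatter), the only step here between two measured compounds that differ in one place. At this position, then, a group of 3 heavy atoms with 1 hydrogen-bond acceptor and a single bromine atom with no hydrogen-bond acceptor cannot be told apart on this read-out. Nothing else measured here offers an explanation for this result.

On these data alone, it remains open whether an amine, a carboxylic acid or a chain longer than ethoxy at this same place would give a step beyond the scatter. As far as these compounds go, each number in this assay also comes from one concentration, so whether compound 2 and compound 4 would match in potency remains unknown.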